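The source may report more compounds than this note shows. Statements on the series, on what has been measured and on what is new or still open speak of the compounds shown alone.

Working notes on the series. Compound 1 `CCOC(=O)C1=Cc2ccccc2OC1(OCc1cn(-c2ccc(F)cc2)nn1)C(F)(F)F` gives 9100 nM in a functional assay on MCF7 cells (Homo sapiens) for inhibition, read by MTT assay, with a stated time of 24 h; a higher number here means a weaker inhibitor, a lower number a stronger inhibitor. Within the data shown here, compound 3 `CCOC(=O)C1=Cc2ccccc2OC1(OCc1cn(-c2ccc(C)cc2)nn1)C(F)(F)F` differs from compound 1 by methyl in place of fluoro on an aromatic carbon; in this assay compound 3 gives 26700 nM, and the step of a 2.9-fold higher number from compound 1 to compound 3 (0.47 log units; beyond the scatter) is the only single-change step measured so far. Compound 2 `CCOC(=O)C1=Cc2ccccc2OC1(OCc1cc(-c2ccc(OC)cc2)no1)C(F)(F)F` reaches only a limit in this assay, > 150000 nM. Among the measured compounds shown here, of the two numbers known, compound 3 holds the higher one, with compound 1 nearest at a step of modest size.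

Compound 4 `CCOC(=O)C1=Cc2ccccc2OC1(OCc1cn(CC(=O)Nc2cccc(F)c2)nn1)C(F)(F)F` is the next to be measured. Its change from compound 3 is ((3-fluorophenyl)carbamoyl)methyl in place of 4-methylphenyl on an aromatic nitrogen. For the measured compounds named here, no measured step covers an exchange of this kind: the one known step, a 2.9-fold higher number from compound 1 to compound 3 (0.47 log units; beyond the scatter), alters only a substituent on the 4-methylphenyl that now leaves, and compound 2, which carries a different five-membered ring, sits at a limit and gives no number to compare. With only a modest step on record and none that touches a change of this size, no direction can be argued. Compound 4 is therefore expected to give 25000 nM in this assay, within 5000 nM to 120000 nM. The expected step of a 1.1-fold lower number from compound 3 to compound 4 (0.03 log units; within the scatter) is taken as none beyond the scatter, with wide uncertainty in either direction.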

Compound 4, half-maximal inhibitory concentration: > 150000 nM
Compound 4: no number, only a limit; the forecaster's own chance of this, stated with the estimate: 20%; middle value at least 6.0-fold (0.77 log units) away from the limit.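

Among these compounds, on the aromatic nitrogen, ((3-fluorophenyl)carbamoyl)methyl in place of 4-methylphenyl gives an at least 5.6-fold higher number from compound 3 to compound 4 (0.74 log units; beyond the scatter) in this assay, and in place of 4-fluorophenyl it gives an at least 16-fold higher number from compound 1 to compound 4 (1.21 log units; beyond the scatter); the earlier compounds showed only a change on the phenyl ring that stays at this position, a 2.9-fold higher number from compound 1 to compound 3 (0.47 log units; beyond the scatter). Among the compounds with a ring of 3 nitrogen, the two with a substituted phenyl directly on this nitrogen give numbers, while the one with the carbamoylmethyl chain does not, although compound 2, with its different five-membered ring and an aryl group, also gives none. Compound 4 reads only as a limit, not a number, so both new steps are lower bounds on the true size of the change: the limit of > 150000 nM in this assay, at which 2 of the 4 values shown sit.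

The compounds shown change the amide, the methylene and the position of the fluorine on the phenyl ring together, so it remains open which of these accounts for the step. A 3-fluorophenyl directly on the nitrogen, or a chain on this nitrogen ending in a carboxylic acid or an amine, remains untested among the compounds shown.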